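Swapping the aryl group on the shared core

The source may report more compounds than this note shows. Statements on the series, on what has been measured and on what is new or still open speak of the compounds shown alone.

Three compounds share a core and differ at a nitrogen on an aromatic ring. In a functional assay on HepG2 cells (Homo sapiens) for antiproliferative activity, read by CCK-8 assay, with a stated time of 72 h, tested at 2 uM (a higher number here means a stronger effect of the compound at the concentration tested, a lower number a weaker effect), compound 1 `Nc1ccccc1NC(=O)c1ccc(Cn2cnc3c(NCc4ccccc4)nc(Cl)nc32)cc1` gives 7.55%, compound 2 `Nc1ccccc1NC(=O)/C=C/c1ccc(Cn2cnc3c(Nc4cccc(OC(F)(F)F)c4)nc(Cl)nc32)cc1` gives 16.2% and compound 3 `Nc1ccccc1NC(=O)c1ccc(Cn2cnc3c(Nc4ccc(-c5ccccn5)cc4)nc(Cl)nc32)cc1` gives 11.5%. Compound 3 stands second of these three, within the scatter of both others. Compound 4 `Nc1ccccc1NC(=O)c1ccc(Cn2cnc3c(Nc4cccc(OC(F)(F)F)c4)nc(Cl)nc32)cc1` carries 3-(trifluoromethoxy)phenyl in place of 4-(pyridin-2-yl)phenyl on a nitrogen on an aromatic ring. For the measured compounds named here, the only measured step at this position, a number 4 percentage points higher from compound 1 to compound 3 (within the scatter), stayed within the scatter; compound 2 carries the same entering group but a different linker, so its value shows only that such a group is compatible with a number in this range. Compound 4 is therefore expected to move by a number 1.5 percentage points higher from compound 3 to compound 4 (within the scatter), no more than the scatter, giving an estimate of 13% with a range of 3% to 25%.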

Compound 4, a percentage reported as inhibition, at one concentration (the size of the read-out at that concentration, not a potency): 1.88%
Estimate against measurement, compound 4: 11.1 percentage points above; the measured number lies below the stated range.
By their numbers in this assay, from the lowest: compounds 4, 1, 3 and 2 (each within the scatter of the next, the first and the last beyond it).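

At the nitrogen on an aromatic ring, 3-(trifluoromethoxy)phenyl in place of 4-(pyridin-2-yl)phenyl gives a number 9.6 percentage points lower from compound 3 to compound 4 (within the scatter), and in place of benzyl gives a number 5.7 percentage points lower from compound 1 to compound 4 (within the scatter), so neither swap separates these compounds in this assay. The clearer change lies elsewhere: with 3-(trifluoromethoxy)phenyl held constant, (2-aminophenyl)carbamoyl in place of 2-((2-aminophenyl)carbamoyl)ethenyl on an aromatic carbon gives a number 14.3 percentage points lower from compound 2 to compound 4 (beyond the scatter). No available evidence bears on this result. Going by these compounds, whether this step would recur with benzyl on the nitrogen remains open, as does how a longer alkyl chain there would read.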